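The compounds below may be only part of what the source reports. "The series", "measured", "known", "first", "only" and "open" are said of these compounds alone.

Compound 1 `O=C1O[C@H]([C@@H](O)Cn2cc(-c3ccc(Br)cc3)nn2)C(OCc2ccccc2)=C1OCc1ccccc1` — 5100 nM
Compound 2 `CCCCc1cn(C[C@H](O)[C@H]2OC(=O)C(OCc3ccccc3)=C2OCc2ccccc2)nn1` — 26300 nM
Compound 3 `CCCCCc1ccc(-c2cn(C[C@H](O)[C@H]3OC(=O)C(OCc4ccccc4)=C3OCc3ccccc3)nn2)cc1` — > 100000 nM

All three were tested in an ADME assay on HFF cells (Homo sapiens) for cytotoxicity, read by MTT assay, with a stated time of 72 h; on this read-out lower numbers stand for stronger inhibition and higher numbers for weaker inhibition. Compound 3 stands at the limit of > 100000 nM in this assay, at which 1 of the 3 values shown sits. That value for compound 3 is a limit of the assay, not a number, so its place on the scale is known only as a range.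

Compound 4 `O=C1O[C@H]([C@@H](O)Cn2cc(CNS(=O)(=O)c3ccc(F)cc3)nn2)C(OCc2ccccc2)=C1OCc1ccccc1` is the unmeasured member; it differs from compound 3 by (((4-fluorophenyl)sulfonyl)amino)methyl in place of 4-pentylphenyl on an aromatic carbon. Two measured steps lead into compound 3 and bear on this change: an at least 3.8-fold higher number from compound 2 to compound 3 (0.58 log units; beyond the scatter) and an at least 19-fold higher number from compound 1 to compound 3 (1.29 log units; beyond the scatter). Both introduce the pentyl-bearing aryl group and both raise the number. The step to compound 4 takes that 4-pentylphenyl away again, so a fall from the limit is expected, though nothing measured here resembles the entering (((4-fluorophenyl)sulfonyl)amino)methyl group, and the size of the fall is uncertain. Compound 4 is therefore estimated at 30000 nM, within 8000 nM to 100000 nM. That estimate for compound 4 means a step of an at least 3.3-fold lower number from compound 3 to compound 4 (0.52 log units; beyond the scatter).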

Compound 4, half-maximal inhibitory concentration: 30 nM
The estimate for compound 4 lay 1000-fold (3.00 log units) above the measured number; measured number below the stated range.
By their numbers in this assay, from the lowest: compound 4; then compound 1; then compound 2. At a limit, above all of these: compound 3.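

In this assay, going by these compounds alone, the aromatic carbon of the five-membered aromatic ring with 3 nitrogen, which bore only aryl or butyl groups in the earlier compounds, now carries (((4-fluorophenyl)sulfonyl)amino)methyl, and the number falls well beyond anything those compounds showed: a 170-fold lower number from compound 1 to compound 4 (2.23 log units; beyond the scatter) and an 880-fold lower number from compound 2 to compound 4 (2.94 log units; beyond the scatter). The largest change is an at least 3300-fold lower number from compound 3 to compound 4 (3.52 log units; beyond the scatter), although the leaving and entering groups each hold one six-membered aromatic ring of carbon only, so the presence of such a ring does not by itself set the number here. Compound 3 stands at a limit of the assay, not a number: the limit of > 100000 nM in this assay, at which 1 of the 4 values shown sits.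

The compounds shown leave open which part of the entering group carries these steps. An amide in place of the sulfonyl group, or a plain phenyl in place of the 4-fluorophenyl, would begin to separate them.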